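The source may hold more compounds than are shown below. What is called first, only, known or untested is meant among the compounds shown, and "the series" means these compounds.

Working notes on the series, read in an ADME assay on L929 cells (Mus musculus) for cytotoxicity, read by MTT assay, with a stated time of 72 h; a higher number here means a weaker inhibitor, a lower number a stronger inhibitor. Compound 1 `Cc1ccc(S(=O)(=O)n2cc(COC3=C/C(=N\c4ccc(Br)cc4)c4ccccc4C3=O)nn2)cc1` reads > 20000 nM, which is a limit of the assay and not a number. Going by the values given here, compound 2 `Cc1ccc(/N=C2\C=C(OCc3cn(S(=O)(=O)c4ccc(C)cc4)nn3)C(=O)c3ccccc32)cc1` gives 17700 nM, the only actual number so far in this assay.

The next change leads to compound 3 `COc1ccc(/N=C2\C=C(OCc3cn(S(=O)(=O)c4ccc(C)cc4)nn3)C(=O)c3ccccc32)cc1`, not yet measured: methoxy in place of methyl on an aromatic carbon. In words, this is methoxy in place of methyl on an aromatic carbon, para to a large group, or 4-methylphenyl to 4-methoxyphenyl.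

Among the compounds with values here, one measured step bears on this, made at the same aromatic carbon: an at least 1.1-fold lower number from compound 1 to compound 2 (0.05 log units; that floor lies within the scatter). As far as these compounds go, its true size stays open because of the limit of > 20000 nM in this assay, at which 1 of the 2 values shown sits. That step shows no change beyond the scatter, so no step beyond the scatter is expected in this assay here, and no direction can be assigned with confidence. A single step is thin support, and a limit reading remains possible.

The expected move is a 1.2-fold lower number from compound 2 to compound 3 (0.07 log units; within the scatter). For compound 3 the estimated value is 15000 nM, with an expected range of 7000 nM to 22000 nM.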

Compound 3, half-maximal inhibitory concentration: > 20000 nM
Compound 3: a limit, no number; the forecaster's own chance of this, stated with the estimate: 20%; middle value at least 1.3-fold (0.12 log units) from the limit.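

In this assay compound 3 gives > 20000 nM, a limit of the assay and not a number. Methoxy in place of methyl on an aromatic carbon gives an at least 1.1-fold higher number from compound 2 to compound 3 (0.05 log units; that floor lies within the scatter), so this change shows no step beyond the scatter, and methoxy joins bromo as a second group at this aromatic carbon that reads as a limit, with methyl in compound 2 the only group here to give a number. As far as these compounds go, the step from compound 1 to compound 3 cannot be read, and the true size of the step from compound 2 to compound 3 also stays open, because the readings sit at the top of the range: the limit of > 20000 nM in this assay, at which 2 of the 3 values shown sit.

With compound 2 at 17700 nM as the only number in the set, the compounds shown do not tell how far a change at this aromatic carbon can move the value in either direction. From the compounds shown here alone, what an amine, a carboxylic acid or a longer chain would read at this same carbon remains open.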